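A few compounds are considered here, and "the series" means these few. Any claim that something is new, unique, unknown or untested is made for them only; others in the source may bear on it.

In a functional assay on MV4-11 cells (Homo sapiens) for inhibition, read by resazurin assay, with a stated time of 72 h (a lower number here means a stronger inhibitor of growth, a higher number a weaker inhibitor of growth), compound 1 `O=[N+]([O-])c1cccc(Nc2ncc3c(n2)CCCC3)c1` gives 3500 nM and compound 2 `COc1cccc(Nc2ncc3c(n2)CCCC3)c1` gives 2280 nM while compound 3 `c1ccc(Nc2ncc3c(n2)CCCC3)cc1` gives 9830 nM as the highest of the three numbers. Compound 4 `CCc1cccc(Nc2ncc3c(n2)CCCC3)c1` has ethyl in place of hydrogen on an aromatic carbon of compound 3, meta to a large group, with ethyl in place of hydrogen on an aromatic carbon as the counted change. Among the measured compounds shown here, two measured steps bear on it: a 2.8-fold higher number from compound 1 to compound 3 (0.45 log units; beyond the scatter) and a 4.3-fold higher number from compound 2 to compound 3 (0.63 log units; beyond the scatter) are both modest and both leave compound 3 higher, while a 1.5-fold lower number from compound 1 to compound 2 (0.19 log units; within the scatter) leaves those two substituents unseparated. Ethyl itself is untested, so a modest step to a lower number is expected in this assay on the strength of these two substituents alone. The estimated step is a 3.0-fold lower number from compound 3 to compound 4 (0.47 log units; beyond the scatter) in this direction. For compound 4 the expected value is 3300 nM with an estimated range from 1400 nM to 7500 nM.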

Compound 4, concentration for 50% growth inhibition: 2600 nM
Estimate against measurement, compound 4: 1.3-fold (0.10 log units) above; the measured number falls inside the stated range.
By their numbers in this assay, from the lowest: compounds 2, 4 and 1 (each within the scatter of the next); then compound 3.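

In this assay, ethyl at this position also improves on the unsubstituted compound 3, with a 3.8-fold lower number from compound 3 to compound 4 (0.58 log units; beyond the scatter), so the lower number is not confined to the two heteroatom-bearing substituents. Ethyl, methoxy and nitro stay unseparated here, with a 1.1-fold higher number from compound 2 to compound 4 (0.06 log units; within the scatter) and a 1.3-fold lower number from compound 1 to compound 4 (0.13 log units; within the scatter), so these three compounds show no preference among the groups. Nothing measured here gives a reason for these steps. Open, from the compounds shown here alone, is whether a longer chain such as propyl, or an amine, at this position would move the number further, and whether ethyl on another aromatic carbon would give the same step.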